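A few compounds are considered here, and "the series" means these few. Any claim that something is new, unique, unknown or untested is made for them only; others in the source may bear on it.

Measured so far in an ADME assay on MT4 cells (Homo sapiens) for activation, read by MTT assay; a higher number here means that more compound is tolerated, a lower number that less compound is tolerated:
Compound 1 `CCc1c(C(C)c2c(F)cccc2F)nc(SC(C)C)[nH]c1=O`: > 3000 nM
Compound 2 `CCc1c(C(C)c2c(F)cccc2F)nc(SC(C)CC)[nH]c1=O`: > 3000 nM
Compound 3 `CCCCSc1nc(C(C)c2c(F)cccc2F)c(CC)c(=O)[nH]1`: > 3000 nM

Compound 3 stands at > 3000 nM, which is a limit of the assay and not a number. Within the data shown here, it shares that position with the other two compounds, and the series so far reads as follows: the limit of > 3000 nM in this assay, at which 3 of the 3 values shown sit.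

Compound 4 `CCc1c(C(C)c2c(F)cccc2F)nc(SC2CCCC2)[nH]c1=O` has cyclopentyl in place of butyl on a sulfur.

The measured steps that bear on this change also alter the group on the sulfur. They are a step that the two limits leave unreadable from compound 1 to compound 3 and a step that the two limits leave unreadable from compound 2 to compound 3, together with a step that the two limits leave unreadable from compound 1 to compound 2. None of the three has a readable size, so they give no direction and no magnitude to carry over. What they do show is that all three groups tried on the sulfur so far end at the same limit. Compound 4 is therefore expected to behave like compound 3 in this assay, with no step beyond the scatter anticipated in either direction, and it may well be reported only as a limit again. The estimated change is a step that the limit leaves unreadable from compound 3 to compound 4. For compound 4 the estimated value is 5000 nM, with an expected range from 2000 nM to 30000 nM.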

Compound 4, half-maximal cytotoxic concentration: > 3000 nM
Compound 4: no number, only a limit; the forecaster's own chance of this, stated with the estimate: 75%; the middle value lies beyond the limit too.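

Compound 4 stands at > 3000 nM in this assay, which is a limit of the assay and not a number, and its steps from compound 1, compound 2 and compound 3 cannot be read. The series now reads: the limit of > 3000 nM in this assay, at which 4 of the 4 values shown sit.

The compounds shown leave open whether the four groups on the sulfur differ at all in this assay.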